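Thiophenesulfonamide to dichlorophenylsulfonamide: malate dehydrogenase series notes

The source may hold more compounds than are shown below. What is called first, only, known or untested is meant among the compounds shown, and "the series" means these compounds.

Measured so far:
compound 1 `O=S(=O)(Nc1ccc(-c2nc3ccccc3o2)cc1)c1cccs1` — > 63000 nM
compound 2 `O=S(=O)(Nc1ccc2oc(-c3ccccc3)nc2c1)c1cccs1` — > 63000 nM

In an assay on isolated protein for inhibition of malate dehydrogenase, mitochondrial (Sus scrofa), with stated times of 45 min and 30 min (on this read-out higher numbers stand for weaker inhibition and lower numbers for stronger inhibition), compound 1 gives > 63000 nM, which is a limit of the assay and not a number. Compound 2 likewise reaches only a limit in this assay, > 63000 nM. Compound 1 therefore stands at the limit of > 63000 nM in this assay, at which 2 of the 2 values shown sit, and no ordering between compound 1 and compound 2 can be read from these two limits.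

Compound 3 `O=S(=O)(Nc1ccc(-c2nc3ccccc3o2)cc1)c1ccc(Cl)c(Cl)c1` is the next member to be examined. It differs from compound 1 by 3,4-dichlorophenyl in place of thiophen-2-yl on a sulfonyl sulfur. Among the measured compounds shown here, no measured step in this assay involves this change, so the expectation rests on the limit for compound 1 alone. The step that the limit leaves unreadable from compound 1 to compound 3 is estimated to be none beyond the scatter in this assay. Compound 3 is accordingly expected to give about 70000 nM in this assay, within 15000 nM to 300000 nM, most probably reported again only as a limit.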

Compound 3, half-maximal inhibitory concentration: > 63000 nM
Compound 3: no number, only a limit; the forecaster's own chance of this, stated with the estimate: 80%; the middle value does not contradict the limit.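

Compound 3, like compound 1, reaches only a limit in this assay, so no step from compound 1 to compound 3 can be read: the limit of > 63000 nM in this assay, at which 3 of the 3 values shown sit.

The compounds shown leave open whether 3,4-dichlorophenyl and thiophen-2-yl on a sulfonyl sulfur differ at all in this assay.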